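Ether variation on the aryl ring: cytotoxicity notes

A few compounds are considered here, and "the series" means these few. Any claim that something is new, unique, unknown or untested is made for them only; others in the source may bear on it.

Measured so far:
compound 1, `CCOC(=O)c1c(-c2cccc(OCC)c2)[nH]c2cc(OC)ccc2c1=O`: > 22000 nM
compound 2, `CCOC(=O)c1c(-c2cccc(OC(C)C)c2)[nH]c2cc(OC)ccc2c1=O`: > 22000 nM

In an ADME assay on HEK293 cells (Homo sapiens) for cytotoxicity, read by luminescence, with a stated time of 72 h (a lower number here means that less compound is needed, a higher number that more compound is needed for the effect), compound 1 reaches only the limit > 22000 nM. Compound 2 likewise reaches only the limit > 22000 nM. The step that the two limits leave unreadable from compound 1 to compound 2 is therefore not readable, since both values sit at the limit of > 22000 nM in this assay, at which 2 of the 2 values shown sit. Compound 3, `CCOC(=O)c1c(-c2cccc(OC(F)(F)F)c2)[nH]c2cc(OC)ccc2c1=O`, differs from compound 2 by trifluoromethyl in place of isopropyl on an oxygen on an aromatic ring. Among the measured compounds shown here, no measured step bears on this change, and the values at hand are limits only. Compound 3 is expected to behave the same way, with an estimated 30000 nM (from 15000 nM to 80000 nM), which means an estimated step that the limit leaves unreadable from compound 2 to compound 3 that stays within the scatter.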

Compound 3, half-maximal effective concentration: > 22000 nM
Compound 3 gave a limit, no number (the forecaster's own chance of this, stated with the estimate: 85%); the middle value is on the limit's open side.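

No step among compound 1, compound 2 and compound 3 can be read, because each value is a limit and not a number: the limit of > 22000 nM in this assay, at which 3 of the 3 values shown sit.

On these data alone, whether ethoxy, isopropoxy and trifluoromethoxy differ at all in cytotoxicity remains open.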